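Methyl on a phenol oxygen, tested in a second core

A few compounds are considered here, and "the series" means these few. Any claim that something is new, unique, unknown or untested is made for them only; others in the source may bear on it.

In a functional assay on HL-60 cells (Homo sapiens) for cytotoxicity, read by WST assay, with a stated time of 48 h (a higher number here means that more compound is needed for the effect, a lower number that less compound is needed), three compounds have been measured so far. Compound 1 `COc1ccc(C[C@H]2COC(=O)[C@@H]2Cc2ccc(Cl)c(Cl)c2)cc1O` gives 32000 nM, and compound 2 `COc1ccc(C[C@H]2COC(=O)[C@@H]2Cc2ccc(Cl)c(Cl)c2)cc1OC`, which carries methyl in place of hydrogen on an oxygen on an aromatic ring, gives 24000 nM. That change produced a 1.3-fold lower number from compound 1 to compound 2 (0.12 log units; within the scatter). Compound 3 `Oc1ccccc1C[C@H]1COC[C@@H]1Cc1ccc(Cl)c(Cl)c1` is built on a different core; the difference between the core of compound 1 and the core of compound 3 is not broken down here. In this assay compound 3 gives 34000 nM, a value that sits within the scatter of both compound 1 and compound 2.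

Compound 4 `COc1ccccc1C[C@H]1COC[C@@H]1Cc1ccc(Cl)c(Cl)c1` has not yet been measured. It differs from compound 3 by methyl in place of hydrogen on an oxygen on an aromatic ring, the same change as from compound 1 to compound 2, and the place reads the same for both pairs: on an oxygen on an aromatic ring whose other neighbours are aromatic carbon. Because the earlier step was a 1.3-fold lower number from compound 1 to compound 2 (0.12 log units; within the scatter), the step expected in this assay is a 1.3-fold lower number from compound 3 to compound 4 (0.10 log units; within the scatter), an expectation that rests on that single precedent and on the value of compound 3. Compound 4 is therefore expected to give about 27000 nM, with a likely range from 13000 nM to 55000 nM.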

Compound 4, half-maximal effective concentration: 55000 nM
Compound 4: middle estimate off by 2.0-fold (0.31 log units), on the low side; measured number inside the range.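

In this assay, methyl in place of hydrogen on an oxygen on an aromatic ring gave a 1.6-fold higher number from compound 3 to compound 4 (0.21 log units; within the scatter), so on this core too the change stays within the usual scatter. Set beside the earlier step, the two results cannot be told apart, even though they point in opposite directions: the same change on two cores in this assay, a 1.3-fold lower number (0.12 log units; within the scatter) from compound 1 to compound 2 and a 1.6-fold higher number (0.21 log units; within the scatter) from compound 3 to compound 4, 2.2-fold (0.33 log units) apart, within the scatter of two such steps. This shows that, for these two pairs, going from hydroxy to methoxy moves the number no further than repeat measurements would, and that no difference between the two cores can be claimed; it does not show that the two cores truly respond alike, nor that the direction of the step depends on the core, and two pairs cannot set a rule for the series.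

The pairs shown compare only hydrogen and methyl on that oxygen. From the compounds shown here alone, whether an ethyl group, a longer chain or a chain ending in an amine at the same place would move the number beyond the scatter stays open.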